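This account rests on a few compounds, and the source may have more. Where it says the series, first, only, none or still open, it means among the compounds named here.

Compounds measured so far:

Compound 1, `COc1ccccc1N1CCN(CCCNc2ccc(C(=O)N(C)C)cn2)CC1`, 31.6 nM
Compound 2, `COc1ccccc1N1CCN(CCCNc2ccccc2C(=O)c2ccccc2)CC1`, 10 nM
Compound 3, `CN(C)C(=O)c1cccnc1NCCCN1CCN(c2ccccc2)CC1`, 15.9 nM

In a functional assay on aorta for antagonist activity at Alpha-1D adrenergic receptor (Rattus norvegicus) (a lower number here means tighter binding, a higher number weaker binding), compound 3 gives the second highest of the three numbers. Its nearest neighbour is compound 2, and the gap between the two lies within the scatter; compound 1 stands furthest from it, yet that gap too lies within the scatter, so the three compounds cannot be told apart on these numbers.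

Compound 4, `COc1ccc(N2CCN(CCCNc3ncccc3C(=O)N(C)C)CC2)c(OC)c1`, has not yet been measured. It differs from compound 3 in one place: 2,4-dimethoxyphenyl in place of phenyl on an amine nitrogen in a ring. For the measured compounds named here, no step between measured compounds shows what such a change does. The expected step from compound 3 to compound 4 in this assay, a 1.6-fold higher number from compound 3 to compound 4 (0.20 log units; within the scatter), is small, toward a higher number, and most likely within the scatter. Compound 4 is therefore estimated at 25 nM, with a range from 8 nM to 80 nM.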

Compound 4, dissociation constant: 1000 nM
Beside the measured number, compound 4's estimate is 40-fold (1.60 log units) below it; the measured number lies above the stated range.
By their numbers in this assay, from the lowest: compounds 2, 3 and 1 (each within the scatter of the next, the first and the last beyond it); then compound 4.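

In this assay the group on the amine nitrogen in the ring is far from a silent spot: 2,4-dimethoxyphenyl in place of phenyl brings a 63-fold higher number from compound 3 to compound 4 (1.80 log units; beyond the scatter) on an otherwise unchanged core. For the compounds shown here, this is the first single-place change, and it shows that binding depends strongly on what this phenyl carries. Nothing available explains the weaker binding.

On these data alone, whether a single methoxy group on this phenyl would do the same remains open on this core. So does the effect of a smaller substituent, such as fluorine or methyl.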